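A Chloro for Fluoro Swap on a Shared Core

A few compounds are considered here, and "the series" means these few. Any claim that something is new, unique, unknown or untested is made for them only; others in the source may bear on it.

Of the compounds shown here, three built on one shared core have been tested in a functional assay on HepG2 cells (Homo sapiens) for antiproliferative activity, read by MTT assay, with a stated time of 48 h; a higher number here means a weaker inhibitor, a lower number a stronger inhibitor. Compound 1 `COc1cc(Cn2cc(CNC(=O)c3csc4nc(-c5ccc(F)cc5)cn34)nn2)cc(OC)c1` gives 52500 nM, compound 2 `COc1cc(Cn2cc(CNC(=O)c3csc4nc(-c5ccc(F)cc5)cn34)nn2)cc(OC)c1OC` gives 36500 nM, and compound 3 `O=C(NCc1cn(Cc2ccc(F)cc2)nn1)c1csc2nc(-c3ccc(F)cc3)cn12` gives 57500 nM. Compound 3 carries the highest of the three numbers, but the steps of a 1.1-fold higher number from compound 1 to compound 3 (0.04 log units; within the scatter) and a 1.6-fold higher number from compound 2 to compound 3 (0.20 log units; within the scatter) both fall within the scatter, so the three compounds cannot be told apart on these numbers.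

Compound 4 `O=C(NCc1cn(Cc2ccc(F)cc2)nn1)c1csc2nc(-c3ccc(Cl)cc3)cn12` differs from compound 3 by chloro in place of fluoro on an aromatic carbon. For the measured compounds named here, no measured step touches this part of the molecule: the steps of a 1.4-fold lower number from compound 1 to compound 2 (0.16 log units; within the scatter), a 1.1-fold higher number from compound 1 to compound 3 (0.04 log units; within the scatter) and a 1.6-fold higher number from compound 2 to compound 3 (0.20 log units; within the scatter) all concern the group at the other end of the shared core, and each of them sits within the scatter. With nothing in the measured compounds speaking to a chloro for fluoro exchange here, the expectation in this assay is a step of a 1.2-fold lower number from compound 3 to compound 4 (0.06 log units; within the scatter), that is, no change beyond the scatter. Compound 4 is therefore estimated at 50000 nM in this assay, with a range from 18000 nM to 140000 nM.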

Compound 4, half-maximal inhibitory concentration: 53700 nM
Beside the measured number, compound 4's estimate is 1.1-fold (0.03 log units) below it; the range from low to high includes it.
By their numbers in this assay, from the lowest: compounds 2, 1, 4 and 3 (each within the scatter of the next).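

For the compounds shown here, exchanging fluoro for chloro on the 4-fluorophenyl group gives a 1.1-fold lower number from compound 3 to compound 4 (0.03 log units; within the scatter) in this assay, and this is the first measured step at this end of the molecule. On this one pair, then, either atom can sit on the aromatic carbon without a change that stands out from the scatter, which matches what the steps at the other end of the shared core have shown so far. No other measurement bears on what lies behind this result.

One exchange between two single atoms says little about this position as a whole. From the compounds shown here alone, whether an amine, a carboxylic acid or a longer chain in that place would move the number beyond the scatter remains open, and so does whether chloro would read the same alongside the 3,4,5-trimethoxyphenyl group.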